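A few compounds are considered here, and "the series" means these few. Any claim that something is new, unique, unknown or untested is made for them only; others in the source may bear on it.

Measured compounds:
compound 1, `O=C1C2=C(C(=O)c3ncccc31)C1(CS2)NC(=O)N(c2ccc(Cl)cc2)C1=O`: 2 nM in a functional assay on HT-29 cells (Homo sapiens) for antiproliferative activity, read by MTT assay, with a stated time of 96 h; on this read-out higher numbers stand for weaker inhibition and lower numbers for stronger inhibition
compound 2, `CCN(CC)c1ccc(N2C(=O)NC3(CSC4=C3C(=O)c3ncccc3C4=O)C2=O)cc1`: 50 nM in this assay
compound 3, `CCc1ccc(N2C(=O)NC3(CSC4=C3C(=O)c3ncccc3C4=O)C2=O)cc1`: 1 nM in this assay

Within this set compound 1 has the second highest of the three numbers. Compound 3 is nearest: the step of a 2.0-fold lower number from compound 1 to compound 3 (0.30 log units; within the scatter) is within the scatter, so the two cannot be ordered against each other. Compound 2 is furthest, the step of a 25-fold higher number from compound 1 to compound 2 (1.40 log units; beyond the scatter) being large and beyond the scatter; the same diethylamino group also shows in a 50-fold lower number from compound 2 to compound 3 (1.70 log units; beyond the scatter).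

Compound 4, `CCCCCc1ccc(N2C(=O)NC3(CSC4=C3C(=O)c3ncccc3C4=O)C2=O)cc1`, differs from compound 1 as follows: pentyl in place of chloro on an aromatic carbon. The step that bears on it is a 2.0-fold lower number from compound 1 to compound 3 (0.30 log units; within the scatter), where ethyl replaced chloro on an aromatic carbon and the number stayed within the scatter. For the measured compounds named here, the only step that moved the number, a 25-fold higher number from compound 1 to compound 2 (1.40 log units; beyond the scatter), concerns diethylamino and not an alkyl chain. Going by the values given here, no measured step covers a chain as long as pentyl, so the expectation rests on the ethyl case alone and carries added uncertainty. For compound 4 the expected step of a 1.5-fold higher number from compound 1 to compound 4 (0.18 log units; within the scatter) is small, most likely within the scatter. Compound 4 is estimated at 3 nM, range 0.8 nM to 15 nM.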

Compound 4, half-maximal inhibitory concentration: 250 nM
Compound 4: middle estimate off by 83-fold (1.92 log units), on the low side, and the stated range ends below it.
By their numbers in this assay, from the lowest: compounds 3 and 1 (each within the scatter of the next); then compound 2; then compound 4.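

In this assay this position on the aromatic ring does not accept every alkyl group alike: ethyl stood within the scatter of chloro, yet pentyl in place of chloro gives a 130-fold higher number from compound 1 to compound 4 (2.10 log units; beyond the scatter) and, against the ethyl compound, the longer chain gives a 250-fold higher number from compound 3 to compound 4 (2.40 log units; beyond the scatter) on the same core. The diethylamino group no longer marks the weak end of the set, since pentyl in its place gives a 5.0-fold higher number from compound 2 to compound 4 (0.70 log units; beyond the scatter) in the same direction. No measurement at hand accounts for this loss.

The compounds shown leave open where between ethyl and pentyl the number starts to rise, which a propyl or butyl chain would settle. Going by these compounds, whether a branched tert-butyl group or a pentyloxy chain follows pentyl also remains open.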